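A few compounds are considered here, and "the series" means these few. Any claim that something is new, unique, unknown or untested is made for them only; others in the source may bear on it.

In an ADME assay on Huh-7 cells (Homo sapiens) for cytotoxicity, read by a luciferase reporter and WST assay, with a stated time of 3 days (on this read-out higher numbers stand for lower toxicity in this test and lower numbers for higher toxicity in this test), compound 1 (`Cc1ccc(NC(=O)c2c(NO)cc(-c3ccc(F)cc3)oc2=O)cc1`) gives > 20000 nM, which is a limit of the assay and not a number. Its chloro counterpart, compound 2 (`Cc1ccc(NC(=O)c2c(NO)cc(-c3ccc(Cl)cc3)oc2=O)cc1`), gives > 20000 nM, again a limit. The evidence so far therefore amounts to the limit of > 20000 nM in this assay, at which 2 of the 2 values shown sit.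

Compound 3 (`O=C(NCCO)c1c(NO)cc(-c2ccc(F)cc2)oc1=O`) keeps the core of compound 1 but carries 2-hydroxyethyl in place of 4-methylphenyl on an amide-type nitrogen. An aromatic ring thus gives way to a short chain with no ring.

For the measured compounds named here, only one measured step is available, and it offers little guidance. The step that the two limits leave unreadable from compound 1 to compound 2 is a change of chloro in place of fluoro on an aromatic carbon, elsewhere in the molecule, and it has no readable size. Going by the values given here, no measured step involves the amide-type nitrogen, so the expectation rests on compound 1 alone, which shows no toxicity that can be read as a number.

The expected change, a number no higher from compound 1 to compound 3 (the limit leaves the size open), is none beyond the scatter. For compound 3 the estimate is 20000 nM, with an expected range from 10000 nM to 40000 nM.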

Compound 3, half-maximal cytotoxic concentration: > 20000 nM
Compound 3: no number, only a limit (the forecaster's own chance of this, stated with the estimate: 85%); the middle value sits exactly at the limit.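

In this assay compound 3 gives > 20000 nM, which is a limit of the assay and not a number. Compound 1 also stands at a limit, so the step from compound 1 to compound 3 cannot be read. The compounds shown leave open whether 2-hydroxyethyl and 4-methylphenyl on the amide-type nitrogen differ at all in this test.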